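The source may report more compounds than this note shows. Statements on the series, on what has been measured and on what is new or still open speak of the compounds shown alone.

Measured in a functional assay on HO8910 cells (Homo sapiens) for inhibition, read by MTT assay, with a stated time of 24 h, tested at 100 ug/mL (on this read-out lower numbers stand for less inhibition of growth and higher numbers for more inhibition of growth at the one concentration tested), so far:
compound 1 `O=C(CCCCC1CCSS1)Nc1ccc(Cl)cn1` gives 68.6%
compound 2 `O=C(CCCCC(S)CCS)Nc1ccccc1` gives 13.7%
compound 3 `O=C(CCCCC(S)CCS)Nc1ccccn1` gives 14.2%

Compound 3 sits within the scatter of compound 2 and well beyond the scatter from compound 1. The next compound is compound 4 `O=C(CCCCC(S)CCS)Nc1ccc(Cl)cn1` and the change is chloro in place of hydrogen on an aromatic carbon on the ring of compound 3. Going by the values given here, the only measured step is a number 0.5 percentage points higher from compound 2 to compound 3 (within the scatter) and it comes from a different change, pyridin-2-yl in place of phenyl on an amide-type nitrogen. Among the compounds with values here, no measured pair isolates the chloro. Compound 1 also carries chloro but differs from compound 4 in its chain, so compound 1 at 68.6% only leaves some room on the upper side. No step beyond the scatter is expected in this assay and any drift is expected to be upward. The estimated step is a number 5.8 percentage points higher from compound 3 to compound 4 (within the scatter) on present evidence. Compound 4 is expected at 20% with an estimated range from 8% to 42% in this read-out.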

Compound 4, percent growth inhibition at one concentration: 71.2%
Compound 4: the middle estimate sits 51.2 percentage points below what was measured; the measured number lies above the stated range.
By their numbers in this assay, from the lowest: compounds 2 and 3 (each within the scatter of the next); then compounds 1 and 4 (each within the scatter of the next).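

In this assay, going by these compounds alone, chloro in place of hydrogen on an aromatic carbon, two atoms from the ring nitrogen and para to a large group, gives a number 57 percentage points higher from compound 3 to compound 4 (beyond the scatter), so this position of the ring responds strongly to this change, which the one earlier step, on the ring type, did not reveal. With the chloro in place, the open chain carrying two thiols and the five-membered ring with two sulfur atoms are not told apart, at a number 2.6 percentage points higher from compound 1 to compound 4 (within the scatter). The data shown offer no measured basis for explaining the size of the chloro step.

As far as these compounds go, whether the step is particular to chloro stays open, as bromo or methoxy on the same carbon could show. Also open, from the compounds shown here alone, is whether the same chloro gives a comparable step on the phenyl ring of compound 2.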